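Dihalophenyl exchange on an oxadiazoline antiproliferative scaffold

The source may hold more compounds than are shown below. What is called first, only, known or untested is meant among the compounds shown, and "the series" means these compounds.

Measured compounds:
compound 1, `COc1cc(C2=NN(C(C)=O)C(c3ccc(F)c(F)c3)O2)cc(OC)c1OC`, 46.9%
compound 2, `COc1cc(C(=O)N/N=C/c2ccc(Cl)c([N+](=O)[O-])c2)cc(OC)c1OC`, 42.3%

In a functional assay on PC-3 cells (Homo sapiens) for antiproliferative activity, read by MTT assay, tested at 5 uM (on this read-out lower numbers stand for a weaker effect and higher numbers for a stronger effect at the one concentration tested), compound 1 gives 46.9%. Compound 2, which shares the trimethoxyphenyl part but carries a different core, gives 42.3% in this assay. The two numbers lie within the usual scatter of repeated measurements of each other, so neither compound can be set apart from the other on these data.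

Compound 3, `COc1cc(C2=NN(C(C)=O)C(c3ccc(Cl)c(Cl)c3)O2)cc(OC)c1OC`, has not yet been measured in this assay. It differs from compound 1 in one place: 3,4-dichlorophenyl in place of 3,4-difluorophenyl on a saturated ring carbon. The saturated ring carbon that carries the aryl group is otherwise unchanged, as is the acetyl group on the five-membered ring.

Going by the values given here, no pair of measured compounds shows this exchange, so no measured step can guide the expectation. The step of a number 2.1 percentage points higher from compound 1 to compound 3 (within the scatter) is expected to be small, not beyond the scatter, with no clear direction. For compound 3 the estimate in this assay is 49%, with a range from 34% to 64%.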

Compound 3, a percentage reported as inhibition, at one concentration (the size of the read-out at that concentration, not a potency): 26.1%
Compound 3: middle estimate off by 22.9 percentage points, on the high side; measured number below the stated range.
By their numbers in this assay, from the lowest: compound 3; then compounds 2 and 1 (each within the scatter of the next).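

The exchange on this saturated ring carbon shows that the position is not indifferent to which halogens the aryl group carries: in this assay, 3,4-dichlorophenyl in place of 3,4-difluorophenyl gives a number 20.8 percentage points lower from compound 1 to compound 3 (beyond the scatter), although the two groups have the same number of heavy atoms, the same aromatic ring and no hydrogen-bond donors or acceptors. The acetyl group and the rest of the core stay unchanged, so this step isolates a single change, something that compound 1 and compound 2 could not offer, since they differ in their cores. No measurement shown here accounts for why the two groups part in this way.

What the compounds shown leave open is whether the read-out at this position tracks the halogens at all, since only two aryl groups are compared here; an unsubstituted phenyl, a 4-methoxyphenyl or a 4-aminophenyl group on the same carbon would test that. The step also rests on one concentration, so it describes the size of the effect there and leaves open how compound 1 and compound 3 compare in potency.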